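The source may report more compounds than this note shows. Statements on the series, on what has been measured and on what is new or still open speak of the compounds shown alone.

Two measured compounds open the series. Compound 1 `COc1ccc(C2CC(c3ccc(OC)c(OC)c3)=NN2C(=O)CO[N+](=O)[O-])c(OC)c1` carries the 2,4-dimethoxyphenyl group on the saturated ring carbon of the shared core together with a nitrooxy-acetyl chain; in a functional assay on the whole organism (strain albino) for inhibition, with Rattus norvegicus as the target, read by paw edema, with stated times of 30 min and 1 h, at a dose of 100 mg/kg by the oral route (on this read-out higher numbers stand for more inhibition at the one dose given (going by the name of the read-out) and lower numbers for less inhibition), compound 1 gives 38%. Compound 2 `COc1ccc(C2=NN(C(=O)CNc3ccc(/C(C)=N/O)cc3)C(c3ccco3)C2)cc1OC` carries the furan-2-yl group on that carbon together with the oxime-bearing anilino-acetyl chain; in this assay compound 2 gives 38%. Compound 2 therefore stands level with compound 1 at the digits printed, and the gap between them falls within the usual scatter, so no order between the two can be read from these numbers.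

Compound 3 `COc1ccc(C2CC(c3ccc(OC)c(OC)c3)=NN2C(=O)CNc2ccc(/C(C)=N/O)cc2)c(OC)c1` is not yet measured. It departs from compound 2 by 2,4-dimethoxyphenyl in place of furan-2-yl on a saturated ring carbon, so that the acyl chain of compound 2 is kept while the aryl group of compound 1 returns. Going by the values given here, no pair of measured compounds differs in a single place, so no measured step of this kind exists. Given that compound 1 and compound 2 both sit at the same level in this assay, the step of no change at the digits printed from compound 2 to compound 3 (within the scatter) is expected to be small, in no set direction, and to stay within the scatter. Compound 3 is accordingly estimated at 38%, with a range of 26% to 50%.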

Compound 3, a percentage reported as inhibition, in the whole organism at one dose (the size of the read-out at that dose, not a potency): 27%
Beside the measured number, compound 3's estimate is 11 percentage points above it, within the range that was stated.
By their numbers in this assay, from the lowest: compound 3; then compounds 1 and 2 (each within the scatter of the next).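

The level reading of compound 1 and compound 2 gave no sign of whether either place matters, and the new result shows that the aryl place does: with the oxime-bearing anilino-acetyl chain kept, 2,4-dimethoxyphenyl in place of furan-2-yl on a saturated ring carbon gives a number 11 percentage points lower from compound 2 to compound 3 (beyond the scatter) in this assay on this series. The chain place responds as well: with 2,4-dimethoxyphenyl kept on that carbon, the oxime-bearing anilino-acetyl chain in place of the nitrooxy-acetyl chain gives a number 11 percentage points lower from compound 1 to compound 3 (beyond the scatter), so neither place can be treated as indifferent in this small set. Nothing on hand bears on the reason for either step.

Going by these compounds alone, the single aryl swap changes the ring, its size and the methoxy groups together, so these remain inseparable here; plain phenyl or thiophen-2-yl on the same carbon, tested with the same oxime-bearing chain, would begin to separate them. From the compounds shown here alone, whether the furan-2-yl group paired with the nitrooxy-acetyl chain would read differently from compound 1 and compound 2 also stays open.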